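Swapping a Pyridine for a Third Thiophene

The source may hold more compounds than are shown below. What is called first, only, known or untested is meant among the compounds shown, and "the series" means these compounds.

Compound 1 `c1coc(-c2ccnc(-c3cccs3)c2)c1` and compound 2 `c1ccc(-c2cc(-c3cccs3)nc(-c3cccs3)c2)nc1` were both tested in a functional assay on SK-OV-3 cells (Female gonad, Homo sapiens) for antiproliferative activity; a higher number here means that more compound is needed for the effect, a lower number that less compound is needed. Compound 1 gives 118000 nM in this assay. Compound 2 gives 118000 nM in this assay, so on the numbers shown compound 2 stands level with compound 1, with no change at the digits reported and within the usual scatter. For the measured compounds named here, no pair of measured compounds differing in a single place has a step on record, so no measured step guides the next move.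

Compound 3 `c1csc(-c2cc(-c3cccs3)nc(-c3cccs3)c2)c1` is still to be measured. It differs from compound 2 by thiophen-2-yl in place of pyridin-2-yl on an aromatic carbon. Going by the values given here, nothing among the measured compounds points to a shift in either direction, so the step from compound 2 to compound 3 is expected to be no change at the digits printed from compound 2 to compound 3 (within the scatter), none beyond the scatter. Compound 3 is accordingly estimated at 118000 nM in this assay, within a range from 55000 nM to 250000 nM.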

Compound 3, half-maximal effective concentration: 118000 nM
Compound 3: the middle estimate sits on the measured number at the digits printed; measured number inside the range.
By their numbers in this assay, from the lowest: compounds 1, 2 and 3 (each within the scatter of the next).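

For the compounds shown here, putting thiophen-2-yl in place of pyridin-2-yl on the aromatic carbon opposite the ring nitrogen gives no change at the digits printed from compound 2 to compound 3 (within the scatter) in this assay, and this is the first single-place step available. It shows that at this position a six-membered aromatic ring with a nitrogen can give way to a five-membered aromatic ring with a sulfur without any shift in the read-out beyond the scatter. No measurement at hand offers an explanation for this flat result.

Still open, from the compounds shown here alone, is whether any group at this position would move the number at all, and an amine or a carboxylic acid on this carbon would test that. Going by these compounds, it is equally open whether the two thiophen-2-yl groups elsewhere on the core can be exchanged with as little effect.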